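Halogen swaps on the N-aryl ring: compound 4

This account rests on a few compounds, and the source may have more. Where it says the series, first, only, none or still open, it means among the compounds named here.

Compound 3 `COc1cc2c(Oc3ccc(NC(=O)c4nn(-c5ccc(Cl)cc5)c(=O)cc4C)cc3F)ccnc2cc1OCCCN1CCCC1` gives 150 nM in a functional assay on MKN-45 cells (Homo sapiens) for inhibition, read by MTT assay, with a stated time of 72 h; a lower number here means a stronger inhibitor, a higher number a weaker inhibitor. Compound 1 `COc1cc2c(Oc3ccc(NC(=O)c4nn(-c5ccccc5)c(=O)cc4C)cc3F)ccnc2cc1OCCCN1CCCC1` gives 120 nM, and compound 2 `COc1cc2c(Oc3ccc(NC(=O)c4nn(-c5cccc(F)c5)c(=O)cc4C)cc3F)ccnc2cc1OCCCN1CCCC1` gives 120 nM; compound 3 carries the highest of the three numbers, but all three lie within the usual scatter of one another, so no order can be read from them.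

Compound 4 `COc1cc2c(Oc3ccc(NC(=O)c4nn(-c5ccc(F)c(F)c5)c(=O)cc4C)cc3F)ccnc2cc1OCCCN1CCCC1` differs from compound 3 by 3,4-difluorophenyl in place of 4-chlorophenyl on an aromatic nitrogen. For the measured compounds named here, three measured steps bear on this change: no change at the digits printed from compound 1 to compound 2 (within the scatter), a 1.3-fold higher number from compound 1 to compound 3 (0.10 log units; within the scatter) and a 1.3-fold higher number from compound 2 to compound 3 (0.10 log units; within the scatter). Each of these halogen changes on the aryl ring attached to the ring nitrogen left this assay unmoved beyond the scatter. Putting two fluorines on that ring in place of one chlorine is expected to behave the same way, so the expected step is a 1.2-fold lower number from compound 3 to compound 4 (0.06 log units; within the scatter), with no direction beyond the scatter. Compound 4 is therefore estimated at 130 nM, in a range from 65 nM to 260 nM.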

Compound 4, half-maximal inhibitory concentration: 80 nM
The estimate for compound 4 lay 1.6-fold (0.21 log units) above the measured number; the range from low to high includes it.
By their numbers in this assay, from the lowest: compounds 4, 1, 2 and 3 (each within the scatter of the next).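

In this assay, the 3,4-difluorophenyl group on the aromatic nitrogen brings a second halogen onto this ring, and all three new steps stay within the scatter (a 1.9-fold lower number from compound 3 to compound 4 (0.27 log units; within the scatter)) (a 1.5-fold lower number from compound 2 to compound 4 (0.18 log units; within the scatter)) (a 1.5-fold lower number from compound 1 to compound 4 (0.18 log units; within the scatter)). The step from 4-chlorophenyl is the largest printed so far at this position, but it does not pass the scatter, so phenyl, 3-fluorophenyl, 4-chlorophenyl and 3,4-difluorophenyl still cannot be ranked. Nothing at hand gives a reason for any of these numbers.

The compounds shown cover only hydrogen, fluoro and chloro on this ring, so they leave open whether the number stays within the scatter with a methoxy group, an amine or a carboxylic acid there. They also leave open what happens with cyclohexyl in place of the aromatic ring.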